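The source may hold more compounds than are shown below. What is called first, only, known or untested is meant among the compounds shown, and "the series" means these compounds.

Series notes, values in a physicochemical assay for lipophilicity, measured as octanol-water partition; a lower number here means a more polar compound, a higher number a more lipophilic compound:

- compound 1 `COC(=O)c1ccc(/C=C/C(=O)N[C@@H]2O[C@H](CO)[C@@H](O)[C@H](O)[C@H]2O)cc1`: -0.805
- compound 2 `CC[C@H](CC(=O)N[C@@H]1O[C@H](CO)[C@@H](O)[C@H](O)[C@H]1O)c1ccc(C)c(C)c1`: 0.01

Of these two numbers, compound 1 at -0.805 is the lower one. Compound 2 reads 0.01, and the gap between them lies beyond the scatter. Among the measured compounds shown here, they are the only two readings so far, and no measured pair differs in one place alone. The expectation below therefore rests on the structural change and on these two values, not on any measured step.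

The next compound is compound 3 `CCc1ccc(/C=C/C(=O)N[C@@H]2O[C@H](CO)[C@@H](O)[C@H](O)[C@H]2O)cc1`, which keeps the shared core of compound 1 and carries one change: ethyl in place of methoxycarbonyl on an aromatic carbon. In words, this is ethyl in place of methoxycarbonyl on an aromatic carbon, para to a large group.

In this assay the change is expected to move the number upward, toward the more lipophilic end, by more than the scatter. The expected step is a number 1.01 log units higher from compound 1 to compound 3 (beyond the scatter). That expectation would bring the new reading into the neighbourhood of compound 2 at 0.01. For compound 3 the estimated value is 0.2, with an expected range from -0.25 to 0.65.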

Compound 3, partition coefficient: 0.04
The estimate for compound 3 lay 0.16 log units above the measured number; low and high end bracket the measured number.
By their numbers in this assay, from the lowest: compound 1; then compounds 2 and 3 (each within the scatter of the next).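

In this assay, among the compounds shown here, ethyl in place of methoxycarbonyl on an aromatic carbon, para to a large group, gives a number 0.85 log units higher from compound 1 to compound 3 (beyond the scatter) and is the first change that can be read at one place alone. For the compounds shown here, the reading therefore shows that this position of the shared core can move the number beyond the scatter, which the earlier values, with no one-place pair between them, could not show. Methoxycarbonyl leaves with 4 heavy atoms and 2 hydrogen-bond acceptors, ethyl enters with 2 heavy atoms and 0 hydrogen-bond acceptors, and no measurement at hand bears on what drives the step.

A single pair cannot separate the loss of methoxycarbonyl from the arrival of ethyl, so a longer chain such as propyl, a carboxylic acid or an amine on the same aromatic carbon would be needed to show how the number follows the group at this position. As far as these compounds go, whether a step of this size carries over to a different core also remains open.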